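Trimming the Vinyl Group to Methyl: Expected Affinity Shift

The source may report more compounds than this note shows. Statements on the series, on what has been measured and on what is new or still open speak of the compounds shown alone.

Compound 1 `C#Cc1cc(O[C@@H]2CCNC2)cnc1Cl` gives 46 nM in an assay on a protein complex for binding affinity to Neuronal acetylcholine receptor; alpha4/beta2 (Rattus norvegicus); a higher number here means a weaker inhibitor, a lower number a stronger inhibitor.
Compound 2 `C=Cc1cc(O[C@@H]2CCNC2)cnc1Cl` gives 140 nM in this assay.

For the measured compounds named here, compound 2 stands at the highest of the two numbers in this assay; its nearest neighbour is compound 1, and the single measured step, a 3.0-fold higher number from compound 1 to compound 2 (0.48 log units; beyond the scatter), shows that exchanging ethynyl for vinyl weakened binding modestly. Compound 3 `Cc1cc(O[C@@H]2CCNC2)cnc1Cl` has not been measured. It differs from compound 2 by methyl in place of vinyl on an aromatic carbon. Going by the values given here, no measured pair covers a vinyl-to-methyl exchange, so only the ethynyl-to-vinyl step offers a bearing: shortening the substituent once already cost affinity, and a second shortening is expected to cost a little more, or possibly nothing beyond the scatter. Compound 3 is therefore estimated at 220 nM in this assay, with a range from 70 nM to 700 nM. This estimate corresponds to an expected step of a 1.6-fold higher number from compound 2 to compound 3 (0.20 log units; within the scatter).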

Compound 3, half-maximal inhibitory concentration: 64 nM
Estimate against measurement, compound 3: 3.4-fold (0.54 log units) above, outside the stated range (below it).
By their numbers in this assay, from the lowest: compounds 1 and 3 (each within the scatter of the next); then compound 2.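

In this assay trimming vinyl to methyl did not extend the loss seen on the earlier shortening but reversed its direction, giving a 2.2-fold lower number from compound 2 to compound 3 (0.34 log units; beyond the scatter) rather than a further rise. Methyl and ethynyl on this aromatic carbon, ortho to the chloro group, cannot be told apart, with a 1.4-fold higher number from compound 1 to compound 3 (0.14 log units; within the scatter) in the exchange of one for the other, so among these three compounds vinyl alone stands apart and the number does not move in one direction with the length of the substituent. Nothing at hand accounts for vinyl behaving differently from the other two groups.

On these data alone, whether this pattern extends to other groups on the same carbon, such as a nitrile, an ethyl chain or an amine, remains open. The chloro group and the rest of the core are the same in all three compounds, so it is also unknown whether the vinyl result depends on them.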